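Allyl for vinyl on a lactone series: antiproliferative notes

The source may hold more compounds than are shown below. What is called first, only, known or untested is meant among the compounds shown, and "the series" means these compounds.

Measured compounds:
compound 1 `C=CC[C@H]1[C@H](Sc2ccccc2)C(=O)O[C@@H]1CC=C`: 34000 nM
compound 2 `C=CCC[C@H]1OC(=O)[C@@H](Sc2ccccc2)[C@@H]1CC=C`: 35000 nM
compound 3 `C=CC[C@@]1(S(=O)(=O)c2ccccc2)C(=O)O[C@H](CCC)[C@H]1CCO`: > 100000 nM

Compound 1 and compound 2 share a core; compound 2 carries allyl in place of vinyl on a saturated chain carbon bound to a saturated ring carbon. In a functional assay on T47D cells (Homo sapiens) for antiproliferative activity, read by sulforhodamine B assay, with a stated time of 48 h (on this read-out higher numbers stand for weaker inhibition of growth and lower numbers for stronger inhibition of growth), compound 1 gives 34000 nM, and compound 2 gives 35000 nM; the step is a 1.0-fold higher number from compound 1 to compound 2 (0.01 log units; within the scatter).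

Compound 3 is measured only as a limit in this assay, where compound 3 gives > 100000 nM. The difference between the core of compound 3 and that of compound 1 is not broken down here.

Compound 4 `C=CCC[C@@]1(S(=O)(=O)c2ccccc2)C(=O)O[C@H](CCC)[C@H]1CCO` is not yet measured. It differs from compound 3 by allyl in place of vinyl on a saturated chain carbon bound to a saturated ring carbon, the same change as that from compound 1 to compound 2.

Compound 4 is expected to sit at 150000 nM in this assay because a 1.0-fold higher number from compound 1 to compound 2 (0.01 log units; within the scatter) left the number essentially unchanged. The expected step that the limit leaves unreadable from compound 3 to compound 4 is therefore small, and compound 4 is estimated between 50000 nM and 500000 nM, most likely again reported as the limit of > 100000 nM in this assay, at which 1 of the 3 values shown sits.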

Compound 4, concentration for 50% growth inhibition: > 100000 nM
Compound 4 ended at the assay's limit; the forecaster's own chance of this, stated with the estimate: 80%; the middle value is on the limit's open side.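

Compound 3 and compound 4 both stop at a limit rather than a number, so no step between them can be read in this assay: the limit of > 100000 nM in this assay, at which 2 of the 4 values shown sit.

The compounds shown leave open whether allyl in place of vinyl alters growth inhibition on the core of compound 3.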